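Amino in Place of Fluoro on a Kinase Inhibitor Amide

A few compounds are considered here, and "the series" means these few. Any claim that something is new, unique, unknown or untested is made for them only; others in the source may bear on it.

Of the compounds shown here, three have been tested in an assay on isolated protein for inhibition of Rho-associated protein kinase 1 (Homo sapiens), read by scintillation counting, radiometric assay and 33P incorporation, with a stated time of 40 min, in the presence of a further agent that is not named here; on this read-out lower numbers stand for stronger inhibition and higher numbers for weaker inhibition. Compound 1 `COc1cccc(OCC(=O)Nc2cccc(NC(=O)c3ccc(N(C)C)cc3)c2)c1` gives > 10000 nM, which is a limit of the assay and not a number. Compound 3 `CC(C)(C)c1ccc(S(=O)(=O)Nc2cccc(NC(=O)COc3ccc4c(=O)ccoc4c3)c2)cc1` gives > 10000 nM, again a limit. Two of the three values thus sit at the limit of > 10000 nM in this assay, at which 2 of the 3 values shown sit. Compound 2 `O=C(COc1ccc2c(=O)ccoc2c1)Nc1cccc(NC(=O)c2ccc(F)cc2)c1` gives 129 nM, the only measured number shown, so it stands alone with nothing to be compared against. Compound 4 `Nc1ccc(C(=O)Nc2cccc(NC(=O)COc3ccc4c(=O)ccoc4c3)c2)cc1` differs from compound 2 in one place: amino in place of fluoro on an aromatic carbon. Among the compounds with values here, no measured step between compounds differing in one place is available, so no direction for this change is known, and a step no larger than the usual scatter, in either direction, is expected. Compound 4 is therefore estimated at 150 nM, with a range from 40 nM to 600 nM. The expected step is a 1.2-fold higher number from compound 2 to compound 4 (0.07 log units; within the scatter).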

Compound 4, half-maximal inhibitory concentration: 802 nM
Compound 4: middle estimate off by 5.3-fold (0.73 log units), on the low side, and the stated range ends below it.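

In this assay, the change from 4-fluorophenyl to 4-aminophenyl brings a 6.2-fold higher number from compound 2 to compound 4 (0.79 log units; beyond the scatter), which shows that inhibition depends on what this aromatic carbon carries. Compound 4 still gives a measured number and not a limit, so inhibition weakens with amino here but remains measurable. Nothing measured here accounts for the size of this step. Going by these compounds, how a hydroxyl, a methoxy group or a carboxylic acid on the same carbon would compare stays open. So does whether the same change would bring a similar step on a different core.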